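Pyridin-3-yl in place of 3-chlorophenyl

The source may report more compounds than this note shows. Statements on the series, on what has been measured and on what is new or still open speak of the compounds shown alone.

Measured so far in a physicochemical assay for solubility, read by LC-MS, using the shake flask method, measured as thermodynamic solubility, with a stated time of 24 h, at pH 6.5; a lower number here means a less soluble compound, a higher number a more soluble compound
Compound 1 `Nc1ccc(-n2cc(CO[C@H]3O[C@H](CO)[C@@H](O)[C@H](O)[C@@H]3O)nn2)cc1` gives > 2000 ug/mL (a limit)
Compound 2 `OC[C@H]1O[C@H](n2cc(-c3ccccc3)nn2)[C@@H](O)[C@@H](O)[C@@H]1O` gives > 3000 ug/mL (a limit)
Compound 3 `OC[C@H]1O[C@H](n2cc(-c3cccc(Cl)c3)nn2)[C@@H](O)[C@@H](O)[C@@H]1O` gives 705 ug/mL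

Within the data shown here, compound 3 holds the only true number, since the other two results are limits. Compound 4 `OC[C@H]1O[C@H](n2cc(-c3cccnc3)nn2)[C@@H](O)[C@@H](O)[C@@H]1O` has pyridin-3-yl in place of 3-chlorophenyl on an aromatic carbon of the shared core. Among the measured compounds shown here, one measured step bears on this, an at least 4.2-fold lower number from compound 2 to compound 3 (0.62 log units; beyond the scatter), with chloro in place of hydrogen on an aromatic carbon. Compound 4 carries no chloro, so a rise in this assay of similar size or more is expected. The expected step is a 4.3-fold higher number from compound 3 to compound 4 (0.63 log units; beyond the scatter) and the result may again be only a limit. The estimate for compound 4 is 3000 ug/mL (expected range 1200 ug/mL to 8000 ug/mL).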

Compound 4, solubility: 1380 ug/mL
Compound 4: middle estimate off by 2.2-fold (0.34 log units), on the high side, and the stated range covers the measured number.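

In this assay, pyridin-3-yl in place of 3-chlorophenyl gives a 2.0-fold higher number from compound 3 to compound 4 (0.29 log units; within the scatter), so this change does not separate the two compounds. Pyridin-3-yl in place of phenyl on the same aromatic carbon gives an at least 2.1-fold lower number from compound 2 to compound 4 (0.33 log units; beyond the scatter), so a ring without chloro does not by itself restore the level of compound 2. Compound 2 gives > 3000 ug/mL, which is a limit.

Going by these compounds, the full size of that step stays open, as only its lower bound can be read. Also open, on these data alone, is how an amine or a carboxylic acid on this aromatic ring would read.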